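The compounds below may be only part of what the source reports. "The series", "measured", "known", "first", "only" and "open" are said of these compounds alone.

Compound 1, with the structure `Nc1cc(-c2ccc(Cl)cc2)nc2cc(-c3ccccc3)nn12`, was tested in a functional assay on the whole organism (strain Wistar) for inhibition, with Rattus norvegicus as the target, read by paw edema, with stated times of 30 min and 2 h, at a dose of 50 mg/kg by the oral route (on this read-out higher numbers stand for more inhibition at the one dose given (going by the name of the read-out) and lower numbers for less inhibition), where compound 1 gives 13.8%. For the measured compounds named here, the only other compound measured in the same way is compound 2, with the structure `Cc1ccc(-c2cc3nc(-c4ccc(Br)cc4)cc(N)n3n2)cc1`, and in this assay compound 2 gives 56.3%. Of these two numbers, compound 1 stands lowest, and the gap up to compound 2 lies beyond the usual scatter of such measurements. Compound 1 and compound 2 differ in more than one place. Going by the values given here, no single step between them can be read off.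

Compound 3, with the structure `Cc1ccc(-c2cc(N)n3nc(-c4ccccc4)cc3n2)cc1`, differs from compound 1 in one place: methyl in place of chloro on an aromatic carbon. Cut one bond further out, the same difference reads 4-chlorophenyl to 4-methylphenyl. Compound 2 also carries a 4-methylphenyl group, and since compound 2 gives 56.3%, a rise is expected from compound 1 to compound 3 in this assay, of the estimated size a number 14.2 percentage points higher from compound 1 to compound 3 (beyond the scatter), though a change within the scatter cannot be ruled out. For compound 3 the expected value in this assay is 28%, within a range from 8% to 50%.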

Compound 3, a percentage reported as inhibition, in the whole organism at one dose (the size of the read-out at that dose, not a potency): 37.5%
Estimate against measurement, compound 3: 9.5 percentage points below, within the range that was stated.
By their numbers in this assay, from the lowest: compound 1; then compound 3; then compound 2.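

For the compounds shown here, until now, the only two numbers came from compounds that differ in more than one place, so no single change could be weighed. Here a single change gives the first readable step in this assay, with methyl in place of chloro on an aromatic carbon producing a number 23.7 percentage points higher from compound 1 to compound 3 (beyond the scatter), which shows that the group at this spot on the ring, para to a large group, matters to the read-out even though one heavy atom simply replaces another, with no ring, hydrogen-bond donor, hydrogen-bond acceptor or net charge entering or leaving. No measurement of any property of the two compounds or their groups is available to explain this step.

With only chloro and methyl shown at this position, it remains open how groups such as methoxy, an amine or a carboxylic acid would fare there, and whether any of them would give a higher number than methyl. On these data alone, it also remains open whether the same swap from chloro to methyl would give a step of similar size if the phenyl group elsewhere on the core were replaced.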